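Replacing the sulfanyl group in compound 2 with a dimethoxyphenyl ring

The source may report more compounds than this note shows. Statements on the series, on what has been measured and on what is new or still open speak of the compounds shown alone.

Of the compounds shown here, two have been measured in an assay on CHO cells for antagonist activity at transient receptor potential cation channel subfamily V member 1 (Homo sapiens), read by FLIPR; a lower number here means a stronger inhibitor, a higher number a weaker inhibitor. Compound 1 `CCCN(CCC)c1cc(C(F)(F)F)ccc1CNC(=O)C(C)c1ccc(NS(C)(=O)=O)c(F)c1` gives 0.3 nM in this assay. Compound 2 `CC(C(=O)NCc1ccc(C(F)(F)F)cc1SC1CCCCC1)c1ccc(NS(C)(=O)=O)c(F)c1` gives 0.5 nM in this assay, the higher of the two numbers, although the step of a 1.7-fold higher number from compound 1 to compound 2 (0.22 log units; within the scatter) lies within the scatter. Compound 3 `COc1cc(OC)cc(-c2cc(C(F)(F)F)ccc2CNC(=O)C(C)c2ccc(NS(C)(=O)=O)c(F)c2)c1` has not yet been measured. It differs from compound 2 at one place: 3,5-dimethoxyphenyl in place of cyclohexylsulfanyl on an aromatic carbon. Within the data shown here, the only measured step that bears on this position is a 1.7-fold higher number from compound 1 to compound 2 (0.22 log units; within the scatter), where a dipropylamino group and a cyclohexylsulfanyl group on the same aromatic carbon gave numbers within the scatter of each other. Among the measured compounds shown here, that step is small, so it offers no sign that this position tolerates only one kind of group. The 3,5-dimethoxyphenyl group is, however, neither of the two groups already tested there, and the data do not show how an aromatic ring at this place behaves. Compound 3 is therefore expected to stay in the same region, with a step of a 2.4-fold higher number from compound 2 to compound 3 (0.38 log units; beyond the scatter) that may be at or just beyond the scatter. The estimate for compound 3 in this assay is 1.2 nM, within 0.25 nM to 6 nM.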

Compound 3, inhibition constant: 5.8 nM
Compound 3: middle estimate off by 4.8-fold (0.68 log units), on the low side; measured number inside the range.
By their numbers in this assay, from the lowest: compounds 1 and 2 (each within the scatter of the next); then compound 3.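

In this assay, this aromatic carbon, meta to a trifluoromethyl group, proves sensitive to the group it carries: 3,5-dimethoxyphenyl in place of cyclohexylsulfanyl gives a 12-fold higher number from compound 2 to compound 3 (1.06 log units; beyond the scatter), and in place of dipropylamino it gives a 19-fold higher number from compound 1 to compound 3 (1.29 log units; beyond the scatter), whereas the earlier exchange of dipropylamino for cyclohexylsulfanyl stayed within the scatter. Among these compounds, the position therefore does not accept every group equally, and 3,5-dimethoxyphenyl, the only one of the three groups with an aromatic ring, goes with the highest number, although compound 3 still gives 5.8 nM. No measurement shown here accounts for this difference.

The 3,5-dimethoxyphenyl group differs from cyclohexylsulfanyl in both its ring and its oxygen atoms, so the compounds shown leave open whether the higher number goes with the aromatic ring itself or with its two methoxy groups, a question that a plain phenyl ring or a ring with one methoxy group could address. They also leave open how a non-aromatic ring joined through oxygen, such as cyclohexyloxy, or a pyridine ring would compare at this position.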